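Chloro substitution on the thiazole-bound phenyl of the series

The source may report more compounds than this note shows. Statements on the series, on what has been measured and on what is new or still open speak of the compounds shown alone.

Measured so far:
compound 1 `COc1ccc(-c2nc(SCC(=O)c3sc(-c4ccccc4)nc3C)nc(N)c2C#N)cc1` — -4.6%
compound 2 `Cc1nc(-c2ccccc2)sc1C(=O)CSc1nc(N)c(C#N)c(-c2ccc(Cl)cc2)n1` — -23%

In an assay on membranes from CHO cells for displacement of a labelled ligand from adenosine receptor A1 (Homo sapiens), read by scintillation counting, with a stated time of 60 min, tested at 1 uM (on this read-out higher numbers stand for more inhibition at the one concentration tested (going by the name of the read-out) and lower numbers for less inhibition), compound 1 gives -4.6% and stands highest of the two numbers; compound 2, with chloro in place of methoxy on an aromatic carbon, gives -23%, and the step of a number 18.4 percentage points lower from compound 1 to compound 2 (beyond the scatter) is modest but beyond the scatter. Both values sit at or under no inhibition.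

Compound 3 `COc1ccc(-c2nc(SCC(=O)c3sc(-c4ccc(Cl)cc4)nc3C)nc(N)c2C#N)cc1` is not yet measured. It differs from compound 1 by chloro in place of hydrogen on an aromatic carbon, the chlorine entering on an aromatic carbon of a six-membered aromatic ring of carbon only, para to a large group, on the phenyl attached to the thiazole side of the shared core rather than on the phenyl of compound 2. Among the measured compounds shown here, the one measured step concerns a different ring and a different leaving group, so it bears only loosely; with both known numbers near zero, no step beyond the scatter is expected in this assay. Compound 3 is therefore expected to give -8%, between -30% and 14%, a step of a number 3.4 percentage points lower from compound 1 to compound 3 (within the scatter).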

Compound 3, a percentage reported as inhibition, at one concentration (the size of the read-out at that concentration, not a potency): 1.2%
Beside the measured number, compound 3's estimate is 9.2 percentage points below it; the measured number falls inside the stated range.
By their numbers in this assay, from the lowest: compound 2; then compounds 1 and 3 (each within the scatter of the next).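

In this assay, the change from phenyl to 4-chlorophenyl, chloro in place of hydrogen on an aromatic carbon para to a large group, gives a number 5.8 percentage points higher from compound 1 to compound 3 (within the scatter). This position therefore accepts a chlorine without a step beyond the scatter, whereas the earlier chloro in place of methoxy on the other aromatic ring gave a number 18.4 percentage points lower from compound 1 to compound 2 (beyond the scatter). No supporting data bear on this result.

As far as these compounds go, whether another group at this position, such as an amine, a carboxylic acid or a longer chain, would give a step beyond the scatter remains open. Also open is whether the 4-chlorophenyl group would read the same with the methoxy group replaced by chloro, and the read-out at one concentration gives no potency for any of these compounds.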